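Swapping a thiazole amide for an isopropyl sulfonamide

A few compounds are considered here, and "the series" means these few. Any claim that something is new, unique, unknown or untested is made for them only; others in the source may bear on it.

Compound 2 `Cc1nc(C(=O)N2CCc3nc(C#Cc4ccccc4)sc3C2)cs1` holds the only number shown in an assay on HEK293 cells for positive allosteric modulation of metabotropic glutamate receptor 5 (Homo sapiens), read by FLIPR, with a stated time of 1 h (on this read-out lower numbers stand for an effect already at smaller amounts and higher numbers for an effect only at larger amounts of compound), at 220 nM. Compound 1 `CC(=O)N1CCc2nc(C#Cc3ccccc3)sc2C1` gives in this assay only a limit, > 10000 nM, sitting at the limit of > 10000 nM in this assay, at which 1 of the 2 values shown sits. For the measured compounds named here, the sole measured guide is an at least 45-fold lower number from compound 1 to compound 2 (1.65 log units; beyond the scatter), where the 2-methyl-1,3-thiazol-4-yl group on the carbonyl carbon replaced a methyl. Compound 3 `CC(C)S(=O)(=O)N1CCc2nc(C#Cc3ccccc3)sc2C1` carries isopropylsulfonyl in place of (2-methyl-1,3-thiazol-4-yl)carbonyl on an amine nitrogen in a ring. With the ring on the acyl group gone again, a loss is expected, though its size is uncertain: compound 3 is estimated at 3000 nM, between 500 nM and 15000 nM. This is expected to be a step of a 14-fold higher number from compound 2 to compound 3 (1.13 log units; beyond the scatter).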

Compound 3, half-maximal effective concentration: > 10000 nM
Compound 3: a limit, no number (the forecaster's own chance of this, stated with the estimate: 35%); middle value at least 3.3-fold (0.52 log units) from the limit.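

On the amine nitrogen in a ring, isopropylsulfonyl does not replace (2-methyl-1,3-thiazol-4-yl)carbonyl without loss, giving an at least 45-fold higher number from compound 2 to compound 3 (1.65 log units; beyond the scatter). Of the three compounds, only compound 2, with its five-membered aromatic ring, gives a number rather than a limit. Compound 1 and compound 3 both end in a limit, so the step between them cannot be read: the limit of > 10000 nM in this assay, at which 2 of the 3 values shown sit.

From the compounds shown here alone, it remains open whether a benzoyl group on the same nitrogen would give a number. The same is open for a phenylsulfonyl group, which would show whether a ring can work through a sulfonyl link.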